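The compounds below may be only part of what the source reports. "The series", "measured", "known", "first", "only" and "open" are said of these compounds alone.

The measured compounds in an ADME assay on S9 fraction from liver (Rattus norvegicus) for metabolic stability, read by LC-MS, using NADPH, with a stated time of 30 min (a lower number here means that less of the compound is left, a higher number that more of the compound is left), are:

Compound 1 `CCCCCCCCc1ccc(OCC(=O)Cn2nnc(Cc3ccccc3)n2)cc1`, which sits at the limit of < 5%.
Compound 2 `CCCCCCCCc1ccc(OC(C)C(=O)Cn2nnc(-c3ccccc3)n2)cc1`, with 40%.
Compound 3 `CC(Oc1ccc(Oc2ccc(F)cc2)cc1)C(=O)Cn1nnc(-c2ccccc2)n1`, which likewise sits at the limit of < 5%.

Compound 3 thus stands at the floor of what this assay reports, and it shares that position with compound 1, so that (the limit of < 5% in this assay, at which 2 of the 3 values shown sit). For the measured compounds named here, the only numeric value in the set belongs to compound 2, and the one measured step, a number at least 35 percentage points lower from compound 2 to compound 3 (beyond the scatter), is large and carries compound 3 down to the limit.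

Compound 4 `CC(Oc1ccc(Oc2ccc(Cl)cc2)cc1)C(=O)Cn1nnc(-c2ccccc2)n1` differs from compound 3 by chloro in place of fluoro on an aromatic carbon. Going by the values given here, no measured step among the three compounds concerns this exchange of one halogen for another; the measured step from compound 2 to compound 3 concerns the octyl-to-4-fluorophenoxy exchange, not the halogen. With compound 3 already at the limit, no step beyond the scatter is expected in this assay, and a further drop could not be seen in any case.

Compound 4 is therefore expected to remain at or close to the limit, with an estimated 5%, between 0% and 15%, corresponding to an expected step of a number no lower from compound 3 to compound 4 (the limit leaves the size open).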

Compound 4, percent of the compound remaining: < 5%
Compound 4 gave a limit, no number; the forecaster's own chance of this, stated with the estimate: 65%; the middle value sits exactly at the limit.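

In this assay compound 4 gives < 5%, which is a limit and not a number. The large step seen with 4-fluorophenoxy in place of octyl recurs with 4-chlorophenoxy at the same aromatic carbon, giving a number at least 35 percentage points lower from compound 2 to compound 4 (beyond the scatter), so among these compounds the drop from compound 2 does not depend on fluoro alone. The exchange of fluoro for chloro cannot itself be read, because compound 3 and compound 4 both rest at the same limit and any difference between them is hidden: the limit of < 5% in this assay, at which 3 of the 4 values shown sit.

The compounds shown leave open whether the octyl chain is the only group at this aromatic carbon that keeps a readable amount of compound in the assay, or whether a shorter chain such as butyl, a plain phenyl or a benzyloxy group would do the same. They also leave open what a halogen exchange does on the phenoxy ring, since that could be read only from a pair standing clear of the limit, and a methoxy or a carboxylic acid in place of the halogen remains equally untested here.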